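This account rests on a few compounds, and the source may have more. Where it says the series, first, only, none or still open, it means among the compounds named here.

Measured so far:
- compound 1, `CCC[C@@H](OC(C)=O)C1=C(Br)/C(=C/Br)OC1=O`: 1.6 ug/mL
- compound 2, `CCC[C@@H](OC(C)=O)C1=C(Br)C(=C(Br)Br)OC1=O`: a limit, < 0.1 ug/mL
- compound 3, `CCC[C@@H](OC(C)=O)C1=C(Br)[C@@](OC)(C(Br)Br)OC1=O`: 2.8 ug/mL

In a functional assay on ZR-75-1 cells (Homo sapiens) for cytotoxicity (on this read-out higher numbers stand for an effect only at larger amounts of compound and lower numbers for an effect already at smaller amounts), compound 1 gives 1.6 ug/mL and compound 3 gives 2.8 ug/mL; the two lie within the usual scatter of each other, so no order between them is claimed. For compound 2 this assay records only a limit, < 0.1 ug/mL, and not a number. Compound 2 thus stands at the limit of the read-out rather than at a measured value (the limit of < 0.1 ug/mL in this assay, at which 1 of the 3 values shown sits); how far it lies beyond the other two is not known, only that it is beyond them.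

Compound 4, `CCC[C@@H](O)C1=C(Br)C(=C(Br)Br)OC1=O`, is still to be measured in this assay. It differs from compound 2 in one place: hydrogen in place of acetyl on an oxygen on a saturated carbon. For the measured compounds named here, no measured pair covers this kind of change, so there is no step to lean on. The expectation is a small move, either none beyond the scatter or a modest shift toward larger amounts, since the rest of the core of compound 2 is kept. Compound 4 is therefore estimated at 0.15 ug/mL, with a range from 0.04 ug/mL to 0.6 ug/mL. The expected step of an at least 1.5-fold higher number from compound 2 to compound 4 (0.17 log units; that floor lies within the scatter) is small, and a limit rather than a number remains a real possibility for compound 4.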

Compound 4, concentration for half-maximal effect: 0.3 ug/mL
The estimate for compound 4 lay 2.0-fold (0.30 log units) below the measured number; the measured number falls inside the stated range.
By their numbers in this assay, from the lowest: compound 4; then compounds 1 and 3 (each within the scatter of the next). At a limit, below all of these: compound 2.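

In this assay, the change from acetoxy to hydroxy, on an oxygen on a saturated carbon, gives an at least 3.0-fold higher number from compound 2 to compound 4 (0.47 log units; beyond the scatter). For the compounds shown here, this is the only step that reads this place, and it shows that the acetyl is not a silent part of compound 2: taking it off moves the number beyond the scatter, while compound 4 still gives 0.3 ug/mL. The true size of the step stays open-ended, since compound 2 carries a limit and not a number: the limit of < 0.1 ug/mL in this assay, at which 1 of the 4 values shown sits.

The compounds shown leave open whether the same change would act in the same direction on the core of compound 1 or of compound 3, as a single step on either core is not available here. They also leave open what other groups on this oxygen would do, such as a methyl ether or a longer ester like butyrate, or what an amine in place of the hydroxy would give at this saturated carbon.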